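The source may report more compounds than this note shows. Statements on the series, on what has been measured and on what is new or still open speak of the compounds shown alone.

Compound 1 `O=C(CCCCCCc1ccccc1)c1ncc(-c2cccc(O)c2)o1` gives 50 nM in an assay (Rattus norvegicus) for inhibition of Fatty-acid amide hydrolase 1 (Homo sapiens); a higher number here means a weaker inhibitor, a lower number a stronger inhibitor. Within the data shown here, compound 2 `NC(=O)c1cccc(-c2cnc(C(=O)CCCCCCc3ccccc3)o2)c1` gives 6 nM in this assay, the change an 8.3-fold lower number from compound 1 to compound 2 (0.92 log units; beyond the scatter) being the only measured step; compound 2 thus stands as the lower of the two numbers. Compound 3 `O=C(CCCCCCc1ccccc1)c1ncc(-c2cccc(C(=O)C(F)(F)F)c2)o1` differs from compound 2 by trifluoromethyl in place of amino on a carbonyl carbon. Among the measured compounds shown here, the measured step touched the same position but replaced hydroxy, so it bears only loosely here; no step shows what leaving amino does. A modest step is expected, a 2.5-fold higher number from compound 2 to compound 3 (0.40 log units; beyond the scatter), most likely toward a somewhat higher number. Compound 3 is estimated at 15 nM, range 4 nM to 60 nM.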

Compound 3, inhibition constant: 16 nM
Compound 3: middle estimate off by 1.1-fold (0.03 log units), on the low side; the range from low to high includes it.
By their numbers in this assay, from the lowest: compound 2; then compound 3; then compound 1.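

In this assay, among these compounds, the carbamoyl group is not the only group at this place that gives a low number: replacing its amino with trifluoromethyl costs only a 2.7-fold higher number from compound 2 to compound 3 (0.43 log units; beyond the scatter) on the carbonyl carbon. The (trifluoromethyl)carbonyl group also improves on hydroxy, with a 3.1-fold lower number from compound 1 to compound 3 (0.49 log units; beyond the scatter) in the same direction as the earlier carbamoyl step, so both carbonyl-bearing groups give lower numbers than hydroxy. Nothing available accounts for either step. Going by these compounds, how a carboxylic acid, a nitrile or a methyl ketone would read at this place remains open.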